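Alkyl chain extension on the shared core, compound 4

A few compounds are considered here, and "the series" means these few. Any claim that something is new, unique, unknown or untested is made for them only; others in the source may bear on it.

Compound 1 `O=c1cc(Cn2cc(CCO)nn2)c2ccc(O)cc2o1` in a functional assay on HeLa cells (Homo sapiens) for inhibition, read by MTT assay, with a stated time of 72 h (a higher number here means a weaker inhibitor, a lower number a stronger inhibitor), gives > 100000 nM, a limit of the assay.
Compound 2 `O=c1cc(Cn2cc(CCCCO)nn2)c2ccc(O)cc2o1` gives > 100000 nM, again a limit of the assay.
Compound 3 `CCCCCCc1cn(Cc2cc(=O)oc3cc(O)ccc23)nn1` gives 59000 nM.

Within the data shown here, compound 3 holds the only number in the set; the other two values sit at the limit of > 100000 nM in this assay, at which 2 of the 3 values shown sit. Compound 4 `CCCCCCCCc1cn(Cc2cc(=O)oc3cc(O)ccc23)nn1` differs from compound 3 by ethyl in place of hydrogen on a saturated chain carbon, six bonds along the chain from an aromatic carbon. Among the measured compounds shown here, the steps that bear on it are an at least 1.6-fold lower number from compound 1 to compound 3 (0.22 log units; that floor lies within the scatter) and an at least 1.6-fold lower number from compound 2 to compound 3 (0.22 log units; that floor lies within the scatter), both unreadable beyond a floor that lies within the scatter, and both exchange a hydroxy for an alkyl rather than lengthening an alkyl. For the measured compounds named here, no measured step tests chain length alone. For compound 4 a step of about a 1.5-fold lower number from compound 3 to compound 4 (0.17 log units; within the scatter) is therefore expected, small and downward at most, within the scatter. The estimate for compound 4 is 40000 nM, between 12000 nM and 100000 nM.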

Compound 4, half-maximal inhibitory concentration: 35100 nM
Estimate against measurement, compound 4: 1.1-fold (0.06 log units) above; low and high end bracket the measured number.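

In this assay, among these compounds, ethyl in place of hydrogen, six bonds along the chain from an aromatic carbon, is the only step here that tests alkyl length alone, and it gives a 1.7-fold lower number from compound 3 to compound 4 (0.23 log units; within the scatter); chain length alone therefore remains unresolved. The exchange of hydroxy for alkyl now clears the scatter, with an at least 2.8-fold lower number from compound 2 to compound 4 (0.45 log units; beyond the scatter) and an at least 2.8-fold lower number from compound 1 to compound 4 (0.45 log units; beyond the scatter). Both of these steps are floors that start from a limit: the limit of > 100000 nM in this assay, at which 2 of the 4 values shown sit.

As far as these compounds go, whether a longer chain, or a carboxylic acid in place of the hydroxy, would give a step beyond the scatter remains open.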